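From compound 3 to compound 4: a change at the carbonyl carbon

The source may report more compounds than this note shows. Statements on the series, on what has been measured and on what is new or still open speak of the compounds shown alone.

Three compounds sharing one core were tested in a functional assay on HEK293 cells for agonist activity at probable G-protein coupled receptor 27 (Homo sapiens), read by a luciferase reporter and beta-arrestin recruitment, with a stated time of 10 min; on this read-out higher numbers stand for an effect only at larger amounts of compound and lower numbers for an effect already at smaller amounts. Compound 1 `O=C(Nc1ccc(Cl)cc1Cl)c1ccc(S(=O)(=O)Nc2ccccc2)cc1` gives only a limit there, > 100000 nM. Compound 2 `O=C(Nc1ccc(S(=O)(=O)NCc2ccccc2)cc1)c1ccc(Cl)cc1Cl` likewise gives only a limit, > 100000 nM. For the measured compounds named here, compound 3 `O=C(Nc1ccc(S(=O)(=O)Nc2ccccc2)cc1)c1ccc(Br)cc1F` is the single compound with a measured number in this assay, 479 nM, and therefore stands alone among the values shown. The two other values sit at the limit of > 100000 nM in this assay, at which 2 of the 3 values shown sit. Compound 4 `O=C(Nc1ccc(S(=O)(=O)Nc2ccccc2)cc1)c1cc(F)c(Cl)cc1F` has not yet been measured in this assay. It differs from compound 3 in one place: 4-chloro-2,5-difluorophenyl in place of 4-bromo-2-fluorophenyl on a carbonyl carbon. Going by the values given here, no step between two measured compounds is available to anchor the expectation, since compounds 1 and 2 differ from compound 3 in more than one place. The change keeps the core and exchanges one group for another on the carbonyl carbon, so the step from compound 3 to compound 4 is expected to be small, at most a modest loss, and the estimated step is a 1.7-fold higher number from compound 3 to compound 4 (0.22 log units; within the scatter). Compound 4 is accordingly expected to give about 800 nM in this assay, within an estimated range of 250 nM to 3000 nM.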

Compound 4, half-maximal effective concentration: 141 nM
For compound 4 the middle estimate is 5.7-fold (0.75 log units) above the measured one; measured number below the stated range.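

In this assay, the group on the carbonyl carbon now shows its first readable step: 4-chloro-2,5-difluorophenyl in place of 4-bromo-2-fluorophenyl gives a 3.4-fold lower number from compound 3 to compound 4 (0.53 log units; beyond the scatter). The number therefore responds to an exchange between two halogen-bearing phenyl groups, even though the ring type, the zero counts of hydrogen-bond donors and acceptors, and the absence of net charge all stay the same. Compounds 1 and 2 differ from the others in more than one place, so no steps to them can be read, and both remain limits of the assay: the limit of > 100000 nM in this assay, at which 2 of the 4 values shown sit.

For the compounds shown here, the single step exchanges bromine for chlorine and adds a second fluorine together, so the share of each remains open. Also open, as far as these compounds go, is how the number would respond to a methoxy group, an amine or a carboxylic acid on this ring.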